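Amide Substituent Swap Measured on Two Cores

The source may hold more compounds than are shown below. What is called first, only, known or untested is meant among the compounds shown, and "the series" means these compounds.

Compound 1 `COCCNC(=O)c1cc2cccc(OC)c2oc1=N`: > 70%
Compound 2 `CCC(CO)NC(=O)c1cc2cccc(OC)c2oc1=N`: 24%
Compound 3 `COCCNC(=O)c1cc2cc(Cl)ccc2oc1=N`: 17%

Three compounds were measured in an assay on CHO cells for displacement of a labelled ligand from adenosine receptor A1 (Homo sapiens), read by scintillation counting, with a stated time of 60 min, tested at 10 uM; on this read-out higher numbers stand for more inhibition at the one concentration tested (going by the name of the read-out) and lower numbers for less inhibition. The value of compound 1 is not a number but a limit of the assay, (the limit of > 70% in this assay, at which 1 of the 3 values shown sits). In this assay compound 2 gives 24%. The step between these two is a number at least 46 percentage points lower from compound 1 to compound 2 (beyond the scatter), and the structural change behind it is 1-(hydroxymethyl)propyl in place of 2-methoxyethyl on an amide-type nitrogen.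

In this assay compound 3 gives 17%. The core of compound 3 and the core of compound 1 are not the same, and the difference between the two cores is not broken down here. Compared with compound 2, compound 3 stands within the scatter, so no order between the two can be read.

Compound 4 `CCC(CO)NC(=O)c1cc2cc(Cl)ccc2oc1=N` has not been measured in this assay. It differs from compound 3 by 1-(hydroxymethyl)propyl in place of 2-methoxyethyl on an amide-type nitrogen, which is the same change that separates compound 1 from compound 2, at the same kind of place on the amide-type nitrogen. That change lowered the inhibition markedly once, but compound 3 already stands low, so there is little room for a step of the same size. The expected step from compound 3 to compound 4 is therefore a number 9 percentage points lower from compound 3 to compound 4 (within the scatter), resting on the step of a number at least 46 percentage points lower from compound 1 to compound 2 (beyond the scatter) and on the value of compound 3 as its starting point. Compound 4 is estimated at 8%, with a likely range from 0% to 22%.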

Compound 4, a percentage reported as inhibition, at one concentration (the size of the read-out at that concentration, not a potency): 7%
The estimate for compound 4 lay 1 percentage points above the measured number, and the stated range covers the measured number.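

In this assay, the swap of 2-methoxyethyl for 1-(hydroxymethyl)propyl on the amide-type nitrogen, carried to the second core, reads as a number 10 percentage points lower from compound 3 to compound 4 (within the scatter), and the same change therefore did not carry over at the same size: the same change on two cores in this assay, a number at least 46 percentage points lower (beyond the scatter) from compound 1 to compound 2 and a number 10 percentage points lower (within the scatter) from compound 3 to compound 4, at least 36 percentage points apart, beyond the scatter of two such steps

The value of compound 1 is > 70%, which is a limit of the assay and not a number.

The two pairs show that the large step seen on the core of compound 1 cannot simply be transferred to the core of compound 3, but they do not show what in the two cores sets the steps apart, and, with the new step within the scatter, they give no firm direction for the change on that second core, nor do they tell whether the low starting value of compound 3, 17%, restricts the size of the step.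

The compounds shown leave open how other groups on the amide-type nitrogen, such as a longer chain or a chain ending in an amine or a carboxylic acid, would behave on either core. They also leave open whether the difference between the two steps would hold on any further core in this series, since the comparison rests on a single pair of compounds for each core.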